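Exchanging One Side Group on Compound 2

A few compounds are considered here, and "the series" means these few. Any claim that something is new, unique, unknown or untested is made for them only; others in the source may bear on it.

Of the compounds shown here, two have been measured so far in a functional assay on HL-60 cells (Homo sapiens) for cytotoxicity, read by WST assay, with a stated time of 48 h; on this read-out higher numbers stand for an effect only at larger amounts of compound and lower numbers for an effect already at smaller amounts. Compound 1 `COCOc1ccccc1C[C@H]1C(=O)OC[C@@H]1Cc1ccccc1` gives 76000 nM in this assay. Compound 2 `COc1ccccc1C[C@H]1COC(=O)[C@@H]1Cc1ccc(Cl)c(Cl)c1` gives 14000 nM in this assay, the lowest of the two numbers; the nearest number, that of compound 1, is higher by a margin beyond the usual scatter, so compound 2 shows its effect at smaller amounts than compound 1.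

Compound 3 `O=C1OC[C@H](Cc2ccc(F)c(F)c2)[C@H]1Cc1ccc(Cl)c(Cl)c1` has not yet been measured. It differs from compound 2 in one place: 3,4-difluorophenyl in place of 2-methoxyphenyl on a saturated chain carbon bound to a saturated ring carbon. For the measured compounds named here, no measured pair of compounds shows this particular exchange, so its effect on the read-out is not known from the data at hand, and only a cautious expectation can be formed.

The step of a 1.4-fold lower number from compound 2 to compound 3 (0.15 log units; within the scatter) is expected to be small, around the size of the usual scatter, leaning slightly toward a lower number. Compound 3 is accordingly estimated at 10000 nM in this assay, with a range from 3000 nM to 35000 nM.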

Compound 3, half-maximal effective concentration: 25000 nM
The estimate for compound 3 lay 2.5-fold (0.40 log units) below the measured number, and the stated range covers the measured number.
By their numbers in this assay, from the lowest: compounds 2 and 3 (each within the scatter of the next); then compound 1.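

In this assay, 3,4-difluorophenyl in place of 2-methoxyphenyl on a saturated chain carbon bound to a saturated ring carbon gives a 1.8-fold higher number from compound 2 to compound 3 (0.25 log units; within the scatter), so the two compounds cannot be told apart on this read-out. For the compounds shown here, this is the first pair that differs in one place, and it shows that this position can take a quite different aromatic group, with the hydrogen-bond acceptor of 2-methoxyphenyl gone, without a change larger than repeated measurements of one compound would give. Nothing at hand explains why the number holds, so the result stands as an observation only.

On these data alone, it remains open whether a group of another kind in this place, such as an amine, a carboxylic acid or a longer chain, would move the number beyond the scatter in either direction. As far as these compounds go, with a single exchange to read, it is also open whether removing the methoxy group and adding the fluorine atoms would each leave the number unchanged if taken separately, or whether their effects merely offset each other in compound 3.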